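Chloro to hydrogen on the aryl ether: clearance notes

A few compounds are considered here, and "the series" means these few. Any claim that something is new, unique, unknown or untested is made for them only; others in the source may bear on it.

Measured compounds:
- compound 1, `Cc1cnc(NC(=O)CCCOc2cncc(Cl)c2)s1`: 86 mL.min-1.g-1
- compound 2, `N#Cc1cnc(NC(=O)CCCOc2cccc(Cl)c2)s1`: 115 mL.min-1.g-1
- compound 3, `Cc1cnc(NC(=O)CCCOc2cccc(C#N)c2)s1`: 172 mL.min-1.g-1

All three share a core carrying a four-carbon amide-ether chain to an aryl ring. In an ADME assay on microsomes from liver (Homo sapiens) for metabolic stability, read by LC-MS, using NADPH, tested at 1 uM (a higher number here means faster removal of the compound, a lower number slower removal), compound 1 gives 86 mL.min-1.g-1, compound 2 gives 115 mL.min-1.g-1 and compound 3 gives 172 mL.min-1.g-1. Compound 2 stands second highest of the three, but its gaps to compound 1 and to compound 3 both lie within the scatter, so no order among them can be read with confidence.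

Compound 4, `N#Cc1cnc(NC(=O)CCCOc2ccccc2)s1`, differs from compound 2 by hydrogen in place of chloro on an aromatic carbon; cut one bond further out, the change reads 3-chlorophenyl to phenyl. Going by the values given here, no measured pair shows the effect of such a change, so nothing here fixes the direction. The step is expected to be small, at most slightly upward, and likely within the scatter: the expected step is a 1.2-fold higher number from compound 2 to compound 4 (0.07 log units; within the scatter). For compound 4 the estimated value in this assay is 135 mL.min-1.g-1, with a range from 70 mL.min-1.g-1 to 260 mL.min-1.g-1.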

Compound 4, intrinsic clearance in microsomes in the Homo sapiens assay: 198 mL.min-1.g-1
Estimate against measurement, compound 4: 1.5-fold (0.17 log units) below; the range from low to high includes it.
By their numbers in the Homo sapiens assay, from the lowest: compounds 1, 2, 3 and 4 (each within the scatter of the next, the first and the last beyond it).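

Going by these compounds alone, in the Homo sapiens assay, hydrogen in place of chloro on an aromatic carbon gives a 1.7-fold higher number from compound 2 to compound 4 (0.24 log units; within the scatter), the first direct reading of 3-chlorophenyl to phenyl, and on this single pair the chloro shows no effect on removal that can be told from the scatter. In a physicochemical assay for solubility, read by nephelometry, at pH 2 (a higher number here means a more soluble compound, a lower number a less soluble compound), compound 2 gives < 1600 nM, which is a limit of the assay, so the step to compound 4 cannot be read: the limit of < 1600 nM in the physicochemical assay, at which 1 of the 2 values shown sits. In the physicochemical assay compound 4 gives 1100 nM.

From the compounds shown here alone, whether the same change reads alike on another core, or with the ring nitrogen of compound 1 present, remains open. Also open, going by these compounds, is whether a different group at this place, such as an amine or a carboxylic acid, would give a step beyond the scatter.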